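Aryl swap on the sulfonyl of a trifluoromethyl hydroxyamide series

The compounds below may be only part of what the source reports. "The series", "measured", "known", "first", "only" and "open" are said of these compounds alone.

Compound 1 `CC(O)(C(=O)Nc1ccc(S(=O)(=O)c2ccccc2C#N)cc1)C(F)(F)F` gives 1100 nM in a functional assay (Cavia porcellus) with sulfonylurea receptors; K-ATP channels (Homo sapiens) as the target (a lower number here means a stronger inhibitor, a higher number a weaker inhibitor), the lowest of the three numbers recorded. Compound 3 `Cc1cc(NC(=O)C(C)(O)C(F)(F)F)ccc1S(=O)(=O)c1ccccc1` gives 1600 nM, within the scatter of compound 1. Compound 2 `COc1cc(NC(=O)C(C)(O)C(F)(F)F)ccc1S(=O)(=O)c1ccccc1` gives 5900 nM, a clear step beyond the scatter from compound 1. For the measured compounds named here, the only measured single-place step, a 3.7-fold lower number from compound 2 to compound 3 (0.57 log units; beyond the scatter), concerns a substituent on the anilide ring, not the ring on the sulfonyl sulfur.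

Compound 4 `Cc1ccc(S(=O)(=O)c2ccc(NC(=O)C(C)(O)C(F)(F)F)cc2)cc1` is obtained from compound 1 by 4-methylphenyl in place of 2-cyanophenyl on a sulfonyl sulfur. Going by the values given here, no measured step touches this position, so no direction beyond the scatter can be argued from the series. For compound 4 the value in this assay is therefore expected near 1800 nM, within 600 nM to 5500 nM, corresponding to an expected step of a 1.6-fold higher number from compound 1 to compound 4 (0.21 log units; within the scatter).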

Compound 4, half-maximal inhibitory concentration: > 30000 nM
Compound 4: no number, only a limit (the forecaster's own chance of this, stated with the estimate: 5%); at least 16-fold (1.22 log units) between middle value and limit.
By their numbers in this assay, from the lowest: compounds 1 and 3 (each within the scatter of the next); then compound 2. At a limit, above all of these: compound 4.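

On the sulfonyl sulfur, 4-methylphenyl in place of 2-cyanophenyl gives an at least 27-fold higher number from compound 1 to compound 4 (1.43 log units; beyond the scatter), so the aryl group at this place is not interchangeable in the series. Compound 4 has no number in this assay, only a limit: the limit of > 30000 nM in this assay, at which 1 of the 4 values shown sits.

Open, on these data alone, is whether the step follows the loss of the nitrile, the gain of the methyl, or the change in where the ring is substituted; 2-methylphenyl and 4-cyanophenyl on the sulfonyl sulfur would separate these. As far as these compounds go, how an aryl group bearing an amine or a carboxylic acid would read in this assay also remains open.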